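The compounds below may be only part of what the source reports. "The series", "measured", "known", "first", "only" and "open" are said of these compounds alone.

Measured compounds and their values:
Compound 1, `Cc1cc(-c2c(F)cc3c(=O)c(Cc4ccc(Cl)cc4)cn(C4CC4)c3c2F)cc(C)n1`, 20000 nM;
Compound 2, `COc1ccc(Cc2cn(C3CC3)c3c(F)c(-c4cc(C)nc(C)c4)c(F)cc3c2=O)cc1`, 21000 nM;
Compound 3, `Cc1cc(-c2c(F)cc3c(=O)c(Cc4ccccc4)cn(C4CC4)c3c2F)cc(C)n1`, 7300 nM.

All three share the same core and differ only in the group that sits on the benzyl ring. In a functional assay on P388 cells (Mus musculus) for cytotoxicity (on this read-out lower numbers stand for stronger inhibition and higher numbers for weaker inhibition), compound 3 gives the lowest number of the three: the steps to it were a 2.7-fold lower number from compound 1 to compound 3 (0.44 log units; beyond the scatter) and a 2.9-fold lower number from compound 2 to compound 3 (0.46 log units; beyond the scatter), both beyond the scatter, so on these numbers compound 3 is the most potent of the set.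

Compound 4, `Cc1cc(-c2c(F)cc3c(=O)c(Cc4cc(O)ccc4O)cn(C4CC4)c3c2F)cc(C)n1`, has not yet been measured. Its difference from compound 3 is 2,5-dihydroxyphenyl in place of phenyl on a saturated chain carbon bound to an aromatic carbon.

Among the measured compounds shown here, two measured steps bear on this: both a 2.7-fold lower number from compound 1 to compound 3 (0.44 log units; beyond the scatter) and a 2.9-fold lower number from compound 2 to compound 3 (0.46 log units; beyond the scatter) show that removing a group from the benzyl ring lowered the number, or, read the other way, that putting a group on that ring raised it. Compound 4 puts two hydroxyl groups on the same ring, a change larger than either measured one and not directly covered by them. The expectation is therefore a modest rise in the number, with wide uncertainty, estimated as a 2.1-fold higher number from compound 3 to compound 4 (0.31 log units; beyond the scatter). Compound 4 is estimated at 15000 nM, expected to fall between 5000 nM and 45000 nM.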

Compound 4, half-maximal inhibitory concentration: 360 nM
Beside the measured number, compound 4's estimate is 42-fold (1.62 log units) above it; measured number outside the range, below it.
By their numbers in this assay, from the lowest: compound 4; then compound 3; then compounds 1 and 2 (each within the scatter of the next).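

Compound 4 shows that the benzyl ring is not simply a place where added groups raise the number. In this assay, the chloro of compound 1 and the methoxy of compound 2 each gave a higher number than the bare phenyl ring of compound 3, yet the change to 2,5-dihydroxyphenyl gives a 20-fold lower number from compound 3 to compound 4 (1.31 log units; beyond the scatter) and so goes against that earlier trend. Measured against the two substituted rings the gap is wider still, with a 58-fold lower number from compound 2 to compound 4 (1.77 log units; beyond the scatter) and a 56-fold lower number from compound 1 to compound 4 (1.74 log units; beyond the scatter), so what is placed on this ring can move the number a long way, and nothing at hand explains why this change has so large an effect.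

Still open, on these data alone, is whether a single hydroxyl on the benzyl ring would lower the number as far as two do, and whether two methoxy groups in place of the hydroxyls would keep it low. Also open, as far as these compounds go, are whether an amine on that ring would act in the same direction and whether the low number on these cells would hold on other cell types.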